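Replacing the pyrimidinyl ketone with a plain aldehyde

The source may hold more compounds than are shown below. What is called first, only, known or untested is meant among the compounds shown, and "the series" means these compounds.

Measured compounds:
- compound 1, `CCCCCCCC/C=C\CCCCCCC(=O)c1ccccc1`: > 100000 nM
- compound 2, `CCCCCCCC/C=C\CCCCCCC(=O)c1nc2cccnc2o1`: 11 nM
- compound 3, `CCCCCCCC/C=C\CCCCCCC(=O)c1ccncn1`: 110 nM

In an assay on isolated protein for inhibition of Fatty-acid amide hydrolase 1 (Homo sapiens) (a lower number here means a stronger inhibitor, a higher number a weaker inhibitor), compound 1 gives a value that is only a limit of the assay, > 100000 nM (the limit of > 100000 nM in this assay, at which 1 of the 3 values shown sits). Compound 3 stands at the high end of the two numbers proper; its nearest neighbour is compound 2, and the step of a 10-fold higher number from compound 2 to compound 3 (1.00 log units; beyond the scatter) separates them. The step of an at least 900-fold lower number from compound 1 to compound 3 (2.95 log units; beyond the scatter) shows how much the pyrimidinyl ring itself contributes compared with a plain phenyl ring.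

Compound 4, `CCCCCCCC/C=C\CCCCCCCC=O`, carries formylmethyl in place of (pyrimidin-4-yl)carbonyl on a saturated chain carbon, six bonds along the chain from a double-bonded chain carbon. This removes the whole aromatic ketone head and leaves a shorter aldehyde head on the same fatty chain. Within the data shown here, no measured step covers such a change directly; the steps of an at least 900-fold lower number from compound 1 to compound 3 (2.95 log units; beyond the scatter) and a 10-fold higher number from compound 2 to compound 3 (1.00 log units; beyond the scatter) only show that the head group governs the numbers in this assay. Losing the pyrimidinyl ring is therefore expected to raise the number, and compound 4 is expected to show a 27-fold higher number from compound 3 to compound 4 (1.44 log units; beyond the scatter). The estimate for compound 4 in this assay is 3000 nM, with a likely range from 500 nM to 20000 nM.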

Compound 4, inhibition constant: 190 nM
Estimate against measurement, compound 4: 16-fold (1.20 log units) above; the whole stated range lies above it.
By their numbers in this assay, from the lowest: compound 2; then compounds 3 and 4 (each within the scatter of the next). At a limit, above all of these: compound 1.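

Swapping (pyrimidin-4-yl)carbonyl for formylmethyl on the saturated chain carbon gives, in this assay, a 1.7-fold higher number from compound 3 to compound 4 (0.24 log units; within the scatter), so on this chain the two heads cannot be told apart and the aromatic ring is not needed to reach this level. Against the benzoyl head the same small aldehyde gives an at least 520-fold lower number from compound 1 to compound 4 (2.72 log units; beyond the scatter), which shows that a ring on the carbonyl does not by itself set the number. The value for compound 1 in that comparison is only a limit of the assay: the limit of > 100000 nM in this assay, at which 1 of the 4 values shown sits.

A primary alcohol or a carboxylic acid in place of the aldehyde on the same chain would test whether the carbonyl of the head carries this result. Also open, on these data alone, is whether the aldehyde head keeps its level on a shorter or longer chain, or on a chain without the double bond.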